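A Naphthalen-1-yl Ketone in Place of a Bromophenyl Ketone

This account rests on a few compounds, and the source may have more. Where it says the series, first, only, none or still open, it means among the compounds named here.

Compound 1 `COc1cc(-c2nnc3n2NC(c2ccco2)C(C(=O)c2ccc(Br)cc2)S3)cc(OC)c1OC` carries a 4-bromophenyl group on its carbonyl carbon. In a functional assay on MCF7 cells (Homo sapiens) for cytotoxicity, read by MTT assay, with a stated time of 48 h (on this read-out higher numbers stand for weaker inhibition and lower numbers for stronger inhibition), compound 1 gives only a limit of the assay, > 100000 nM. Going by the values given here, the other measured compound, compound 2 `COc1cc(-c2nnc3n2NC(c2cccs2)C(C(=O)c2ccc(C)cc2)S3)cc(OC)c1OC`, differs from compound 1 at more than one place, so no single step between them can be read; in this assay compound 2 gives 28400 nM. Among the compounds with values here, the one piece of evidence on the measured values is the limit of > 100000 nM in this assay, at which 1 of the 2 values shown sits, which places compound 1 at the limit and gives no step size at all.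

Compound 3 `COc1cc(-c2nnc3n2NC(c2ccco2)C(C(=O)c2cccc4ccccc24)S3)cc(OC)c1OC` has not been measured. It differs from compound 1 by naphthalen-1-yl in place of 4-bromophenyl on a carbonyl carbon. With compound 1 known only as a limit, the step to compound 3 can be judged against that limit alone. The expected step is an at least 1.6-fold lower number from compound 1 to compound 3 (0.22 log units; that floor lies within the scatter), a modest move toward stronger inhibition, though a reading at the limit again remains quite possible. Compound 3 is therefore estimated at 60000 nM, with a range from 15000 nM to 150000 nM.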

Compound 3, half-maximal inhibitory concentration: > 100000 nM
Compound 3 was reported as a limit; the forecaster's own chance of this, stated with the estimate: 40%; middle value at least 1.6-fold (0.22 log units) away from the limit.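

Compound 1 and compound 3 are both known only as limits in this assay, so no step between them can be read, and the change from 4-bromophenyl to naphthalen-1-yl gets no size: the limit of > 100000 nM in this assay, at which 2 of the 3 values shown sit.

The compounds shown leave open how far past that limit compound 1 and compound 3 each lie, and so whether they differ at all.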